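The compounds below may be only part of what the source reports. "The series", "measured", "known", "first", "only" and "open" are said of these compounds alone.

Measured compounds: compound 1 `Cc1ccc(/C=C2\CCCC(CN(C)c3ccccc3)C2=O)cc1` gives 68.2% in a functional assay on the whole organism (strain Kunming) for inhibition, with Mus musculus as the target, in the writhing test, with stated times of 1 h and 15 min, at a dose of 200 mg/kg by the oral route; a higher number here means more inhibition at the dose given (going by the name of the read-out), a lower number less inhibition; compound 2 `Cc1ccc(/C=C2\CCCC(CN(C)c3ccc(C)cc3)C2=O)cc1` gives 76.6%.

Compound 2 gives the highest of the two numbers, with compound 1 nearest, a step of a number 8.4 percentage points higher from compound 1 to compound 2 (within the scatter) that stays within the scatter. Compound 3 `Cc1ccc(/C=C2\CCCC(CN(C)c3cccc(C)c3)C2=O)cc1` is not yet measured. It differs from compound 2 as follows: 3-methylphenyl in place of 4-methylphenyl on an amine nitrogen. Among the compounds with values here, the only measured step, methyl in place of hydrogen on an aromatic carbon, is not the same kind of change as moving the methyl from one position to another; it gave a number 8.4 percentage points higher from compound 1 to compound 2 (within the scatter), within the scatter, so nothing here argues for a change beyond the scatter. Compound 3 is expected to give about 72% (range 58% to 84%), which means an expected step of a number 4.6 percentage points lower from compound 2 to compound 3 (within the scatter), no more than the usual scatter.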

Compound 3, a percentage reported as inhibition, in the whole organism at one dose (the size of the read-out at that dose, not a potency): 75.8%
For compound 3 the middle estimate is 3.8 percentage points below the measured one; the range from low to high includes it.
By their numbers in this assay, from the lowest: compounds 1, 3 and 2 (each within the scatter of the next).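

Moving the methyl on the amine nitrogen, with 3-methylphenyl in place of 4-methylphenyl, gives a number 0.8 percentage points lower from compound 2 to compound 3 (within the scatter) in this assay and so shows that, for these two positions of the methyl on this ring, the read-out at this single dose does not separate the isomers. Methyl in place of hydrogen on an aromatic carbon now has a second instance, a number 7.6 percentage points higher from compound 1 to compound 3 (within the scatter) alongside a number 8.4 percentage points higher from compound 1 to compound 2 (within the scatter) and both steps stay within the scatter, so neither placement of the methyl gives a change that can be told from the unsubstituted phenyl. Nothing measured here bears on why these steps are as small as they are.

From the compounds shown here alone, whether a methoxy group, a chlorine or a carboxylic acid in place of the methyl would move the read-out beyond the scatter remains open. Also open, going by these compounds, is whether replacing the methyl on the amine nitrogen with an ethyl or a longer chain would do so.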